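The compounds below may be only part of what the source reports. "The series", "measured", "known", "first", "only" and "open" are said of these compounds alone.

Of the compounds shown here, two sharing one core have been measured so far. In an ADME assay on HepG2 cells (Homo sapiens) for inhibition, with a stated time of 48 h (a lower number here means that less compound is needed, a higher number that more compound is needed for the effect), compound 1 (`CC(C(=O)N1CCCCC1)N1CCN(S(=O)(=O)c2ccc(C(C)(C)C)cc2)CC1`) gives > 40000 nM, which is a limit of the assay and not a number. In this assay compound 2 (`CC(C(=O)N1CCCc2ccccc21)N1CCN(S(=O)(=O)c2ccc(C(C)(C)C)cc2)CC1`) gives > 40000 nM, and this too is only a limit. Going by the values given here, compound 2 therefore has no numerical position, and the one other value beside it is also a limit. The whole record so far is the limit of > 40000 nM in this assay, at which 2 of the 2 values shown sit.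

Compound 3 (`CC(C(=O)N1CCc2ccccc2C1)N1CCN(S(=O)(=O)c2ccc(C(C)(C)C)cc2)CC1`) has the same atoms as compound 2, joined differently, with 1,2,3,4-tetrahydroisoquinolin-2-yl in place of 1,2,3,4-tetrahydroquinolin-1-yl on a carbonyl carbon.

Among the compounds with values here, the only measured step that bears on this change is a step that the two limits leave unreadable from compound 1 to compound 2, where 1,2,3,4-tetrahydroquinolin-1-yl replaced piperidin-1-yl at the same place. That step offers neither a size nor a direction, so no step beyond the scatter is expected in this assay. The expected step is a number no higher from compound 2 to compound 3 (the limit leaves the size open), with no direction favoured. For compound 3 the estimated value is 40000 nM, with an expected range from 20000 nM to 80000 nM, and a further reading at the limit of the assay is the likeliest outcome.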

Compound 3, half-maximal effective concentration: 29000 nM
Beside the measured number, compound 3's estimate is 1.4-fold (0.14 log units) above it, within the range that was stated.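

In this assay, going by these compounds alone, compound 3 is the first of the three compounds to give a number and not a limit, which shows that a change on the carbonyl carbon alone can bring a reading of this core within the range of the assay. Joining the same atoms differently, with 1,2,3,4-tetrahydroisoquinolin-2-yl in place of 1,2,3,4-tetrahydroquinolin-1-yl, gives an at least 1.3-fold lower number from compound 2 to compound 3 (0.13 log units; that floor lies within the scatter), and the comparison with the piperidin-1-yl group gives an at least 1.3-fold lower number from compound 1 to compound 3 (0.13 log units; that floor lies within the scatter). These are floors only, so the result establishes a numerical reading for one group and no firm size for either change, and the other two compounds stay at one limit: the limit of > 40000 nM in this assay, at which 2 of the 3 values shown sit.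

On these data alone, how far compound 1 and compound 2 truly lie from compound 3 stays open, as does whether the reading depends on this particular arrangement of the fused rings or would also appear with another group on the carbonyl carbon. A morpholin-4-yl group or an open-chain benzylamine at this place could begin to settle that question.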